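A few compounds are considered here, and "the series" means these few. Any claim that something is new, unique, unknown or untested is made for them only; others in the source may bear on it.

Of the compounds shown here, three that share one core have been measured in a functional assay on A549 cells (Homo sapiens) for antiproliferative activity, read by MTT assay, with a stated time of 72 h; a lower number here means a stronger inhibitor, a higher number a weaker inhibitor. Compound 1 `Cc1cccc(NC(=O)C(Cl)Cl)c1` gives 41100 nM. Compound 2 `COc1cccc(NC(=O)C(Cl)Cl)c1` gives 25800 nM. Compound 3 `O=C(Nc1cccc(C(F)(F)F)c1)C(Cl)Cl` gives 12200 nM, the lowest of the three numbers, and its steps to the other two compounds are both beyond the scatter. The larger of them is a 3.4-fold lower number from compound 1 to compound 3 (0.53 log units; beyond the scatter); the smaller is a 2.1-fold lower number from compound 2 to compound 3 (0.33 log units; beyond the scatter). Between the first two compounds the step is a 1.6-fold lower number from compound 1 to compound 2 (0.20 log units; within the scatter).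

Compound 4 `O=C(Nc1cccc(SC(F)(F)F)c1)C(Cl)Cl` differs from compound 3 by a single change: (trifluoromethyl)sulfanyl in place of trifluoromethyl on an aromatic carbon. Among the measured compounds shown here, no measured pair swaps trifluoromethyl for (trifluoromethyl)sulfanyl, so the only guide is that the two steps into compound 3 were modest when the group on this aromatic carbon changed. A change at the same place is therefore expected to move the number by little, in either direction, and most likely within the scatter; the expected step is a 1.4-fold lower number from compound 3 to compound 4 (0.13 log units; within the scatter). Compound 4 is estimated at 9000 nM, with a range from 3500 nM to 25000 nM.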

Compound 4, half-maximal inhibitory concentration: 14100 nM
Estimate against measurement, compound 4: 1.6-fold (0.19 log units) below; the range from low to high includes it.
By their numbers in this assay, from the lowest: compounds 3, 4, 2 and 1 (each within the scatter of the next, the first and the last beyond it).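

In this assay, the (trifluoromethyl)sulfanyl group can take the place of trifluoromethyl on this aromatic carbon with no difference that stands out from the scatter (a 1.2-fold higher number from compound 3 to compound 4 (0.06 log units; within the scatter)). Set against methoxy, its step also stays within the scatter (a 1.8-fold lower number from compound 2 to compound 4 (0.26 log units; within the scatter)), while set against methyl it goes beyond the scatter (a 2.9-fold lower number from compound 1 to compound 4 (0.46 log units; beyond the scatter)), so both fluorine-bearing groups stand clear of methyl, but only trifluoromethyl stands clear of methoxy. Nothing available here explains why these groups compare as they do.

On these data alone, whether an amine or a carboxylic acid on this same aromatic carbon would fall in this range remains open. Also open, as far as these compounds go, is how these groups would compare at any other carbon of the ring, or with a change elsewhere on the shared core.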